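The source may report more compounds than this note shows. Statements on the series, on what has been measured and on what is new or still open speak of the compounds shown alone.

In a functional assay on PC-3 cells (Homo sapiens) for antiproliferative activity, read by WST assay, with a stated time of 3 days (a lower number here means a stronger inhibitor, a higher number a weaker inhibitor), compound 1 `CCOc1c(-c2cc(OC)c(OC)c(OC)c2)oc2ccccc2c1=O` gives 900 nM and compound 2 `CCCCCCOc1c(-c2cc(OC)c(OC)c(OC)c2)oc2ccccc2c1=O` gives 29200 nM. Compound 3 `CCCCCCCOc1c(-c2cc(OC)c(OC)c(OC)c2)oc2ccccc2c1=O` reaches only a limit, > 50000 nM. Along these plain chains the measured steps are a 32-fold higher number from compound 1 to compound 2 (1.51 log units; beyond the scatter), an at least 55-fold higher number from compound 1 to compound 3 (1.74 log units; beyond the scatter) and an at least 1.7-fold higher number from compound 2 to compound 3 (0.23 log units; that floor lies within the scatter). Compound 4 `CCN(CC)CCCOc1c(-c2cc(OC)c(OC)c(OC)c2)oc2ccccc2c1=O` has diethylamino in place of butyl on a saturated chain carbon, three bonds along the chain from an oxygen on an aromatic ring. For the measured compounds named here, none of the measured steps brings in nitrogen, so they bear on this change only indirectly, and a 32-fold higher number from compound 1 to compound 2 (1.51 log units; beyond the scatter) serves as the rough guide to size. A large step to a lower number is expected, estimated as an at least 6.2-fold lower number from compound 3 to compound 4 (0.79 log units; beyond the scatter). Compound 4 is estimated at 8000 nM, with an expected range from 1500 nM to 40000 nM.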

Compound 4, half-maximal inhibitory concentration: 13600 nM
Compound 4: the middle estimate sits 1.7-fold (0.23 log units) below what was measured; the measured number falls inside the stated range.
By their numbers in this assay, from the lowest: compound 1; then compound 4; then compound 2. At a limit, above all of these: compound 3.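

For the compounds shown here, at this place, on a saturated chain carbon three bonds along the chain from an oxygen on an aromatic ring, nitrogen now enters for the first time: in this assay, diethylamino in place of butyl gives an at least 3.6-fold lower number from compound 3 to compound 4 (0.56 log units; beyond the scatter), and diethylamino in place of propyl gives a 2.1-fold lower number from compound 2 to compound 4 (0.33 log units; beyond the scatter). The amine does not restore the short-chain level, with a 15-fold higher number from compound 1 to compound 4 (1.18 log units; beyond the scatter). The first step is only a floor, and compound 3 stands at a limit: the limit of > 50000 nM in this assay, at which 1 of the 4 values shown sits.

From the compounds shown here alone, whether a smaller amine such as dimethylamino, a cyclic amine such as piperidine, or a carboxylic acid at this chain end would bring the number closer to that of compound 1 remains open.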